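Swapping 4-fluorobenzyl for 4-bromophenyl on a sulfonyl sulfur

The source may hold more compounds than are shown below. What is called first, only, known or untested is meant among the compounds shown, and "the series" means these compounds.

In a functional assay on DU-145 cells (Homo sapiens) for inhibition, read by trypan blue exclusion, with a stated time of 72 h (on this read-out higher numbers stand for weaker inhibition and lower numbers for stronger inhibition), compound 1 (`Cn1c(=O)c(S(=O)(=O)Cc2ccc(F)cc2)cc2cnc(Nc3ccc4[nH]ccc4c3)nc21`) gives 30000 nM and shares the high end of the three numbers with compound 3 (`O=c1[nH]c2nc(Nc3ccc4[nH]ccc4c3)ncc2cc1S(=O)(=O)c1ccc(F)cc1F`), which gives 15000 nM within the usual scatter of it. Compound 2 (`Cn1c(=O)c(S(=O)(=O)c2ccc(F)cc2F)cc2cnc(Nc3ccc4sccc4c3)nc21`) reads far lower at 500 nM on the same scale. Compound 4 (`Cn1c(=O)c(S(=O)(=O)c2ccc(Br)cc2)cc2cnc(Nc3ccc4[nH]ccc4c3)nc21`) keeps the core of compound 1 but has 4-bromophenyl in place of 4-fluorobenzyl on a sulfonyl sulfur. For the measured compounds named here, compound 2 and compound 3 also lack 4-fluorobenzyl, but they differ from compound 1 elsewhere too, so no measured pair isolates this change. The expected change is a 5.0-fold lower number from compound 1 to compound 4 (0.70 log units; beyond the scatter) toward stronger inhibition, a moderate and uncertain step. Compound 4 is estimated at 6000 nM with a likely range from 1200 nM to 30000 nM in this assay once measured.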

Compound 4, half-maximal inhibitory concentration: 5000 nM
The estimate for compound 4 lay 1.2-fold (0.08 log units) above the measured number; the measured number falls inside the stated range.
By their numbers in this assay, from the lowest: compound 2; then compound 4; then compounds 3 and 1 (each within the scatter of the next).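

For the compounds shown here, compounds 1 and 4 form the only pair here that differs in one place, so in this assay the change to 4-bromophenyl on the sulfonyl sulfur can be read directly as a 6.0-fold lower number from compound 1 to compound 4 (0.78 log units; beyond the scatter) toward stronger inhibition. The group at this position therefore matters with the rest of compound 1 held constant. No measurement shown here explains the step.

On these data alone, whether the gain comes from losing the benzyl carbon or from exchanging fluorine for bromine remains open. Values for 4-fluorophenyl and 4-bromobenzyl at this position would separate the two.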